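The compounds below may be only part of what the source reports. "The series", "measured", "known", "first", "only" and "open" are said of these compounds alone.

Going by the values given here, in a functional assay on L1210 cells (Mus musculus) for inhibition (a higher number here means a weaker inhibitor, a lower number a stronger inhibitor), compound 2 (`Nc1ncnc2c(N[C@@H]3O[C@H](CO)[C@@H](O)[C@H]3O)ncnc12`) gives 0.8 uM, the lower of the two numbers so far, clearly under compound 1 (`COc1ncnc2c(N[C@H]3O[C@H](CO)[C@@H](O)[C@H]3O)ncnc12`) at 2.9 uM. Compound 3 (`Nc1ncnc2c(N[C@H]3O[C@H](CO)[C@@H](O)[C@H]3O)ncnc12`) has not yet been measured, and it departs from compound 2 in configuration alone: the two compounds have the same atoms and bonds and differ only in configuration as drawn: 1 of 4 stereo elements differ; a stereocentre at a saturated ring carbon is drawn R in compound 2 and S in compound 3. Among the compounds with values here, no measured pair shows what such a change does, so the expectation is a loss of potency beyond the scatter, held with a wide margin. The expected move is a 3.8-fold higher number from compound 2 to compound 3 (0.57 log units; beyond the scatter). In this assay, the estimated value for compound 3 is 3 uM, with an expected range of 0.8 uM to 12 uM.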

Compound 3, concentration for 50% inhibition: 0.38 uM
Estimate against measurement, compound 3: 7.9-fold (0.90 log units) above; measured number outside the range, below it.
By their numbers in this assay, from the lowest: compound 3; then compound 2; then compound 1.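

In this assay, redrawing one stereocentre at a saturated ring carbon from R to S gives a 2.1-fold lower number from compound 2 to compound 3 (0.32 log units; beyond the scatter), so the S form is the stronger inhibitor of this pair. Only that stereocentre can account for the gap, because nothing else separates the two compounds: the fact that compounds 2 and 3 differ only in the configuration as drawn. With the S drawing held, amino in place of methoxy on an aromatic carbon gives a 7.6-fold lower number from compound 1 to compound 3 (0.88 log units; beyond the scatter).

Going by these compounds, whether amino keeps that advantage over methoxy with the stereocentre drawn R stays open. So does what a methylamino group or a thiol on that aromatic carbon would give.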